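A trifluoromethyl swap on a core held at the limit

This account rests on a few compounds, and the source may have more. Where it says the series, first, only, none or still open, it means among the compounds named here.

Compound 1 `Oc1cccc2nccc(O)c12`: > 30000 nM (a limit)
Compound 2 `COc1cc(O)c2c(O)ccnc2c1`: > 30000 nM (a limit)

In a functional assay on HL-60 cells (Homo sapiens) for antiproliferative activity (a higher number here means a weaker inhibitor, a lower number a stronger inhibitor), compound 2 gives > 30000 nM as a limit of the assay and not a number. Compound 1 gives > 30000 nM and that too is only a limit. Both measured compounds therefore sit at the limit of > 30000 nM in this assay, at which 2 of the 2 values shown sit, and neither offers a number to build on. Among the measured compounds shown here, the one measured step is a step that the two limits leave unreadable from compound 1 to compound 2 and it gives no size to carry forward.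

Compound 3 (`COc1cc(C(F)(F)F)c2c(O)ccnc2c1`) differs from compound 2 by trifluoromethyl in place of hydroxy on an aromatic carbon, with trifluoromethyl in place of hydroxy on an aromatic carbon. For the measured compounds named here, no measured step involves this change, so the data favour no direction. The expected step is a number no higher from compound 2 to compound 3 (the limit leaves the size open) and no shift beyond the scatter is predicted. Compound 3 is estimated at 30000 nM, with an expected range from 10000 nM to 60000 nM and another limit the likeliest report.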

Compound 3, half-maximal inhibitory concentration: > 30000 nM
Compound 3: no number, only a limit; the forecaster's own chance of this, stated with the estimate: 75%; the middle value sits exactly at the limit.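

In this assay compound 3 gives > 30000 nM, which is a limit of the assay and not a number. The step from compound 2 to compound 3 therefore cannot be read. The compounds shown leave open whether any change on the shared core gives a measurable value in this assay.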